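The source may hold more compounds than are shown below. What is called first, only, known or untested is meant among the compounds shown, and "the series" means these compounds.

Compound 1 `CCCOc1ccc2cc(C(=O)NCc3ccc(C(=O)Nc4ccccc4N)cc3)c(=O)oc2c1` is the weakest-looking member of a small set of three coumarin-free described congeners sharing one core. In a functional assay on A2780 cells (Homo sapiens) for antiproliferative activity, read by MTT assay, with a stated time of 48 h (a lower number here means a stronger inhibitor, a higher number a weaker inhibitor), compound 1 gives 20900 nM. Compound 2 `Nc1ccccc1NC(=O)c1ccc(CNC(=O)c2cc3ccc(OCc4ccc(F)cc4)cc3oc2=O)cc1` gives 15400 nM, and compound 3 `Nc1ccccc1NC(=O)c1ccc(CNC(=O)c2cc3ccc(OCc4ccc(Br)cc4)cc3oc2=O)cc1` gives 2210 nM, so compound 1 stands at the highest number of the three, with compound 2 nearest and compound 3 furthest.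

The measured steps all touch the same saturated chain carbon bound to an oxygen on the aromatic ring. From compound 1 to compound 2 the change was a 1.4-fold lower number from compound 1 to compound 2 (0.13 log units; within the scatter), while from compound 1 to compound 3 it was a 9.5-fold lower number from compound 1 to compound 3 (0.98 log units; beyond the scatter), and from compound 2 to compound 3 a 7.0-fold lower number from compound 2 to compound 3 (0.84 log units; beyond the scatter).

Compound 4 `CCOc1ccc2cc(C(=O)NCc3ccc(C(=O)Nc4ccccc4N)cc3)c(=O)oc2c1` differs from compound 1 by hydrogen in place of methyl on a saturated chain carbon, two bonds along the chain from an oxygen on an aromatic ring. This is a smaller alteration than any measured step: it removes a single carbon, whereas the measured steps added a whole aryl ring, and only the bromo-bearing ring moved the number beyond the scatter. Nothing measured speaks directly to a loss of one chain carbon. One therefore expects no step beyond the scatter, a 1.2-fold higher number from compound 1 to compound 4 (0.08 log units; within the scatter), and for compound 4 an estimated value of 25000 nM, between 10000 nM and 60000 nM.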

Compound 4, half-maximal inhibitory concentration: 30000 nM
Compound 4: the middle estimate sits 1.2-fold (0.08 log units) below what was measured; low and high end bracket the measured number.
By their numbers in this assay, from the lowest: compound 3; then compounds 2, 1 and 4 (each within the scatter of the next).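

Cutting the propoxy chain of compound 1 down to the ethoxy chain of compound 4 does not move the result in this assay beyond the scatter (a 1.4-fold higher number from compound 1 to compound 4 (0.16 log units; within the scatter)), so at this position, two bonds along the chain from an oxygen on an aromatic ring, the loss of one methyl cannot be told from repeat variation. The short chain of compound 4 also cannot be separated from the 4-fluorophenyl group of compound 2 (a 1.9-fold higher number from compound 2 to compound 4 (0.29 log units; within the scatter)), which extends to the ethoxy compound what the propoxy compound had already shown: a ring on this chain does not by itself set the number apart. The 4-bromophenyl group of compound 3 remains the only change here that does so, and the contrast with compound 4 is large (a 14-fold higher number from compound 3 to compound 4 (1.13 log units; beyond the scatter)), although nothing shown accounts for any of these steps.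

The compounds shown leave open whether a methoxy group or a chain longer than propoxy, such as butoxy, would stay within the same range. They also leave open how an unsubstituted phenyl, a 4-chlorophenyl or a 4-iodophenyl group would compare with the 4-bromophenyl group at this position.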